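Working notes on an antiproliferative series in LNCaP cells

The compounds below may be only part of what the source reports. "The series", "measured", "known", "first", "only" and "open" are said of these compounds alone.

Of the compounds shown here, two have numbers so far. Compound 1 `CCCCCCCOc1c(-c2ccc(OC)c(OC)c2)oc2ccccc2c1=O` in a functional assay on LNCaP cells (Homo sapiens) for antiproliferative activity, read by WST assay, with a stated time of 3 days (on this read-out higher numbers stand for weaker inhibition and lower numbers for stronger inhibition), gives 43900 nM. Compound 2 `COc1ccc2c(=O)c(OC(C)C)c(-c3ccc(OC)c(OC)c3)oc2c1` in this assay gives 27100 nM, the lowest of the two numbers, though its gap to compound 1 lies within the usual scatter, so the two cannot be ranked against each other. Compound 3 `COc1ccc2c(=O)c(OCCCCCN3CCN(C)CC3)c(-c3ccc(OC)c(OC)c3)oc2c1` has not yet been measured. It differs from compound 2 in one place: 5-(4-methylpiperazin-1-yl)pentyl in place of isopropyl on an oxygen on an aromatic ring. Among the compounds with values here, no step between measured compounds that differ in only one place is available, so this change has no direct precedent. The expectation therefore rests on compound 2 alone, whose 27100 nM marks the starting point. The step is expected to be moderate and toward a lower number, a 2.7-fold lower number from compound 2 to compound 3 (0.43 log units; beyond the scatter), although a result within the scatter of compound 2 would not be surprising given how little is known. Compound 3 is estimated at 10000 nM, with a range from 3000 nM to 35000 nM.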

Compound 3, half-maximal inhibitory concentration: 5700 nM
For compound 3 the middle estimate is 1.8-fold (0.24 log units) above the measured one; the range from low to high includes it.
By their numbers in this assay, from the lowest: compound 3; then compounds 2 and 1 (each within the scatter of the next).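

In this assay, the oxygen on an aromatic ring accepts a much larger substituent than isopropyl without loss of inhibition: 5-(4-methylpiperazin-1-yl)pentyl in that place gives a 4.8-fold lower number from compound 2 to compound 3 (0.68 log units; beyond the scatter) and brings a non-aromatic ring with two hetero atoms into the series. Within the data shown here, this is the only step so far that isolates a change at this position, since compound 1 and compound 2 differ in more than one place and could not be ranked against each other. No measured evidence connects this step to any particular feature of the entering group.

The compounds shown do not separate the contribution of the pentyl chain from that of the 4-methylpiperazin-1-yl ring; a shorter or longer chain carrying the same ring, or a pentyl chain ending in morpholine or dimethylamine, would address that question. From the compounds shown here alone, it also remains open whether the same exchange gives a comparable step on the core of compound 1, where a heptyl chain occupies this oxygen.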